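This account rests on a few compounds, and the source may have more. Where it says the series, first, only, none or still open, it means among the compounds named here.

Measured in an ADME assay on L02 cells (Homo sapiens) for cytotoxicity, read by MTT assay, with a stated time of 24 h; on this read-out lower numbers stand for stronger inhibition and higher numbers for weaker inhibition:
- Compound 1 `Cc1ccc(S(=O)(=O)N2C/C(=C\c3cccnc3)C(=O)/C(=C/c3ccccc3F)C2)cc1`: 14900 nM
- Compound 2 `O=C1/C(=C/c2cccnc2)CN(S(=O)(=O)c2ccc(Cl)cc2)C/C1=C\c1ccccc1F`: > 20000 nM (a limit of the assay, not a number)
- Compound 3 `Cc1ccc(S(=O)(=O)N2C/C(=C\c3cccnc3)C(=O)/C(=C/c3ccccc3C(F)(F)F)C2)cc1`: 12300 nM

For the measured compounds named here, only two of the three readings are true numbers, and the gap between them is a 1.2-fold lower number from compound 1 to compound 3 (0.08 log units; within the scatter). Going by the values given here, compound 3 therefore cannot be separated from its one numerical neighbour.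

Compound 4 `O=C1/C(=C/c2cccnc2)CN(S(=O)(=O)c2ccc(Cl)cc2)C/C1=C\c1ccccc1C(F)(F)F` differs from compound 3 by chloro in place of methyl on an aromatic carbon, para to a large group. The same change has been measured once, as an at least 1.3-fold higher number from compound 1 to compound 2 (0.12 log units; that floor lies within the scatter). That figure is only a floor, set by the limit of > 20000 nM in this assay, at which 1 of the 3 values shown sits, so the true size of the step is open. The expectation rests on compound 2, which at > 20000 nM sits at a limit of the assay.

A modest move towards a higher number, meaning weaker inhibition, is expected in this assay. The expected step is a 1.5-fold higher number from compound 3 to compound 4 (0.19 log units; within the scatter). For compound 4 the estimate is 19000 nM, with an expected range of 11000 nM to 32000 nM. A limit reading instead of a number is a real possibility.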

Compound 4, half-maximal inhibitory concentration: 11900 nM
The estimate for compound 4 lay 1.6-fold (0.20 log units) above the measured number; the measured number falls inside the stated range.
By their numbers in this assay, from the lowest: compounds 4, 3 and 1 (each within the scatter of the next). At a limit, above all of these: compound 2.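

In this assay, chloro in place of methyl now gives a step with a number at both ends, a 1.0-fold lower number from compound 3 to compound 4 (0.01 log units; within the scatter), whereas the earlier instance of this change ended at a limit: the same change on two cores in this assay, an at least 1.3-fold higher number (0.12 log units; that floor lies within the scatter) from compound 1 to compound 2 and a 1.0-fold lower number (0.01 log units; within the scatter) from compound 3 to compound 4; the limit leaves it open whether they differ. Trifluoromethyl in place of fluoro, read with chloro on the sulfonyl aryl group, gives an at least 1.6-fold lower number from compound 2 to compound 4 (0.22 log units; that floor lies within the scatter), which is a floor only: the same change on two cores in this assay, a 1.2-fold lower number (0.08 log units; within the scatter) from compound 1 to compound 3 and an at least 1.6-fold lower number (0.22 log units; that floor lies within the scatter) from compound 2 to compound 4; the limit leaves it open whether they differ. From the compounds shown here alone, the reading for compound 2 is a limit and not a number, so the true size of both steps involving it stays unknown: the limit of > 20000 nM in this assay, at which 1 of the 4 values shown sits.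

Still open, going by these compounds, is whether either change has any effect beyond the scatter when compound 2 is left aside. Also open, on these data alone, is how an amine or a carboxylic acid in place of methyl or chloro on that aromatic ring would read in this assay.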